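From Sulfanyl Acid to Carboxyethyl Chain in Compound 2

The source may report more compounds than this note shows. Statements on the series, on what has been measured and on what is new or still open speak of the compounds shown alone.

In a functional assay on the whole organism (strain Hartley) for inhibition, with Cavia porcellus as the target, with stated times of 2 min and 15 min (a lower number here means that less compound is needed, a higher number that more compound is needed for the effect), compound 1 `CCCCC[C@H](O)/C=C/C1CCC(=O)[C@@H]1CCCCSCC(=O)O` gives 0.00507 mg/kg. On the same read-out, compound 2 `CCCCC(C)(C)[C@H](O)/C=C/C1CCC(=O)[C@@H]1CCCCSCC(=O)O` gives 0.0242 mg/kg, and compound 3 `CCCCC(C)(C)[C@@H](O)/C=C/C1CCC(=O)[C@@H]1CCCCSCC(=O)O` gives 0.324 mg/kg. Compound 2 therefore stands in the middle, with the second highest of the three numbers.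

Two measured steps frame that position. Placing 1,1-dimethylpentyl in place of pentyl brings a 4.8-fold higher number from compound 1 to compound 2 (0.68 log units; beyond the scatter). Redrawing a single stereocentre at a saturated chain carbon brings a 13-fold higher number from compound 2 to compound 3 (1.13 log units; beyond the scatter).

Compound 4 `CCCCC(C)(C)[C@H](O)/C=C/C1CCC(=O)[C@@H]1CCCCCCC(=O)O` keeps both the 1,1-dimethylpentyl group and the stereocentre of compound 2. It carries 2-carboxyethyl in place of (carboxymethyl)sulfanyl on a saturated chain carbon, four bonds along the chain from a saturated ring carbon.

Neither measured step touches that place, so neither sizes this change directly or sets its direction. Going by the values given here, they show only that one change in this small set can move the number beyond the scatter, and they give a reason for a wide range. The expected result is a 1.2-fold higher number from compound 2 to compound 4 (0.09 log units; within the scatter), and no step beyond the scatter is firmly expected. In this assay the estimated dose for compound 4 is 0.03 mg/kg, with an expected range from 0.006 mg/kg to 0.15 mg/kg.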

Compound 4, dose for half-maximal effect: 0.00417 mg/kg
The estimate for compound 4 lay 7.2-fold (0.86 log units) above the measured number; measured number outside the range, below it.
By their numbers in this assay, from the lowest: compounds 4 and 1 (each within the scatter of the next); then compound 2; then compound 3.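

In this assay, 2-carboxyethyl in place of (carboxymethyl)sulfanyl brings a 5.8-fold lower number from compound 2 to compound 4 (0.76 log units; beyond the scatter), so this place, on a saturated chain carbon, four bonds along the chain from a saturated ring carbon, is one where a single change moves the number beyond the scatter. The earlier steps shown here touched only the 1,1-dimethylpentyl group and one stereocentre; this step adds that the exchange at the chain, which keeps the same count of heavy atoms and replaces sulfur with carbon, lowers the dose needed while the 1,1-dimethylpentyl group and the stereocentre of compound 2 stay as they are. Nothing available bears on why the step has this size or direction.

The compounds shown leave open how the number would read with an oxygen ether or a sulfone in the chain at this place, or with a longer chain ending in the carboxylic acid. They also leave open whether the same exchange would give a step of similar size with the pentyl group of compound 1 or with the stereocentre of compound 3.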